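Phenethyl in Place of Methoxybenzyl on a Shared Core

This account rests on a few compounds, and the source may have more. Where it says the series, first, only, none or still open, it means among the compounds named here.

The series shares one core and varies the group on the saturated chain carbon bound to an aromatic carbon. Compound 1 `CN(Cc1ccccc1)C(=O)c1cc2c(Cc3ccccc3Cl)n[nH]c2cc1O` carries a chlorobenzyl group, but in a functional assay on A2780 cells (Homo sapiens) for antiproliferative activity, read by resazurin assay, with a stated time of 72 h (a higher number here means a weaker inhibitor, a lower number a stronger inhibitor), compound 1 gives "not determined" (no result reported), that is, no reported result. Compound 2 `CN(Cc1ccccc1)C(=O)c1cc2c(Cc3cccc(Cl)c3)n[nH]c2cc1O` carries the chlorine at another position of that ring, and in this assay compound 2 gives 410 nM. Compound 3 `COc1cccc(Cc2n[nH]c3cc(O)c(C(=O)N(C)Cc4ccccc4)cc23)c1` carries a 3-methoxybenzyl group, and in this assay compound 3 gives "not determined" (no result reported), so no number is reported for it; with one further entry also lacking a number, compound 3 cannot be placed against compound 2 at all. Compound 4 `CN(Cc1ccccc1)C(=O)c1cc2c(CCc3ccccc3)n[nH]c2cc1O` differs from compound 3 as follows: benzyl in place of 3-methoxyphenyl on a saturated chain carbon bound to an aromatic carbon. Within the data shown here, no step between measured compounds is known for this change, so the direction of the step in this assay cannot be read from the data; the author expects no change beyond the scatter relative to what compound 2 shows. For compound 4 the estimate in this assay is 500 nM, with a range from 150 nM to 2000 nM.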

Compound 4, half-maximal inhibitory concentration: 4600 nM
Beside the measured number, compound 4's estimate is 9.2-fold (0.96 log units) below it, outside the stated range (above it).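

In this assay, among these compounds, there is an 11-fold higher number from compound 2 to compound 4 (1.05 log units; beyond the scatter), the first measured step at this saturated chain carbon bound to an aromatic carbon, so on the shared core compound 4 is a weaker inhibitor than compound 2. The change of 3-chlorophenyl to benzyl at this place removes the chlorine and also lengthens the chain, and this single step does not separate the two. Nothing measured here accounts for the size of the step.

Steps involving compound 1 or compound 3 cannot be read, so the 3-methoxybenzyl to phenethyl change itself has no measured size. The compounds shown leave open whether a 3-chlorophenethyl group, which would keep the chlorine on the longer chain, or a still longer chain such as 3-phenylpropyl would give a number closer to that of compound 2.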